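The source may hold more compounds than are shown below. What is called first, only, known or untested is meant among the compounds shown, and "the series" means these compounds.

Going by the values given here, compound 1 `CN(Cc1ccccc1)Cc1ccc[nH]1` gives 20 nM in an assay on mitochondria for inhibition of Amine oxidase [flavin-containing] B (Bos taurus), read by fluorescence (on this read-out lower numbers stand for stronger inhibition and higher numbers for weaker inhibition), the lowest of the two numbers so far. Taking the methyl off the amine nitrogen gives compound 2 `c1ccc(CNCc2ccc[nH]2)cc1`, which in this assay gives 7200 nM; that step, a 360-fold higher number from compound 1 to compound 2 (2.56 log units; beyond the scatter), is the only one measured. Compound 3 `CC(c1ccccc1)N(C)Cc1ccc[nH]1` differs from compound 1 by methyl in place of hydrogen on a saturated chain carbon bound to an amine nitrogen and an aromatic carbon, a change at a different place, so the measured step does not bear on it directly and gives no guide to its size. The expected step is therefore small, a 2.0-fold higher number from compound 1 to compound 3 (0.30 log units; within the scatter), likely inside the usual scatter. Compound 3 is expected to give about 40 nM, with a range from 10 nM to 200 nM.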

Compound 3, inhibition constant: 1500 nM
Beside the measured number, compound 3's estimate is 38-fold (1.57 log units) below it, outside the stated range (above it).
By their numbers in this assay, from the lowest: compound 1; then compound 3; then compound 2.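

In this assay, the saturated chain carbon bound to an amine nitrogen and an aromatic carbon proves sensitive: methyl in place of hydrogen there gives a 75-fold higher number from compound 1 to compound 3 (1.88 log units; beyond the scatter). A single added carbon thus weakens inhibition by a large step, making this a second place in the molecule, after the amine nitrogen, where one methyl matters. No measured evidence shown here accounts for this result.

Still open, going by these compounds, is how a larger group such as ethyl, or a hydroxyl group, would behave at this carbon.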